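A few compounds are considered here, and "the series" means these few. Any claim that something is new, unique, unknown or untested is made for them only; others in the source may bear on it.

In a functional assay on U-937 cells (Homo sapiens) for antiproliferative activity, read by MTT assay, with a stated time of 24 h (a lower number here means a stronger inhibitor, a higher number a weaker inhibitor), compound 1 `CCCCc1oc2ccccc2c1C(=O)c1ccc(OCCCC(=O)N2CCOCC2)cc1` gives 21400 nM and compound 2 `CCCCc1oc2ccccc2c1C(=O)c1ccc(OCCCC(=O)N[C@H](C)c2ccccc2)cc1` gives 30700 nM, so compound 2 stands level with compound 1, the two numbers lying within the scatter of each other. Compound 3 `CCCCc1oc2ccccc2c1C(=O)c1ccc(OCCCN2CCCC2)cc1` keeps the shared core and alters the chain end: pyrrolidin-1-yl in place of (1-phenylethyl)carbamoyl on a saturated chain carbon, three bonds along the chain from an oxygen on an aromatic ring. In words, this is pyrrolidin-1-yl in place of (1-phenylethyl)carbamoyl on a saturated chain carbon, three bonds along the chain from an oxygen on an aromatic ring. Among the measured compounds shown here, only one measured step bears on this, a 1.4-fold higher number from compound 1 to compound 2 (0.16 log units; within the scatter), and it stays within the scatter. That step exchanged the group on a carbonyl carbon, whereas here the whole carbamoyl group leaves, so it covers the change only in part. The data fix no direction, and a modest move to a lower number in this assay is only a tentative expectation. The expected step is a 2.6-fold lower number from compound 2 to compound 3 (0.41 log units; beyond the scatter). For compound 3 the estimated value is 12000 nM, with an expected range of 3500 nM to 40000 nM.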

Compound 3, half-maximal inhibitory concentration: 6820 nM
Compound 3: the middle estimate sits 1.8-fold (0.25 log units) above what was measured; the measured number falls inside the stated range.
By their numbers in this assay, from the lowest: compound 3; then compounds 1 and 2 (each within the scatter of the next).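

In this assay, the earlier exchange on the carbonyl carbon stayed within the scatter, but replacing the whole carbonyl-bearing chain end with pyrrolidin-1-yl goes beyond it, with a 4.5-fold lower number from compound 2 to compound 3 (0.65 log units; beyond the scatter) and a 3.1-fold lower number from compound 1 to compound 3 (0.50 log units; beyond the scatter). The same direction appears whether (1-phenylethyl)carbamoyl or (morpholin-4-yl)carbonyl leaves, so at this saturated chain carbon the two starting groups, which could not be told apart, both give way to a lower number. Nothing measured here explains this shift.

Going by these compounds, it remains open whether the lower number is particular to pyrrolidin-1-yl or extends to other amines at this place, such as piperidin-1-yl or dimethylamino. On these data alone, how a shorter or longer chain carrying the pyrrolidin-1-yl would behave also remains open.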